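The compounds below may be only part of what the source reports. "The series", "measured", "known", "first", "only" and "open" are said of these compounds alone.

Going by the values given here, in a functional assay on A549 cells (Homo sapiens) for antiproliferative activity, read by MTT assay, with a stated time of 48 h (a lower number here means a stronger inhibitor, a higher number a weaker inhibitor), compound 2 `Cc1cccn2cc(-c3nnc(-c4ccccc4)o3)nc12` gives 23400 nM, so far the only actual number. Compound 1 `Brc1ccc(-c2nnc(-c3cn4ccccc4n3)o2)cc1`, which carries a 4-bromophenyl, reads > 50000 nM, and this is a limit of the assay. Compound 3 `Cc1cccn2cc(-c3nnc(-c4ccc(Br)cc4)o3)nc12` takes compound 2 from phenyl to 4-bromophenyl, with bromo in place of hydrogen on an aromatic carbon, para to a large group: bromo in place of hydrogen on an aromatic carbon. Among the compounds with values here, no measured pair isolates this change, so the expected 1.2-fold higher number from compound 2 to compound 3 (0.08 log units; within the scatter) is none beyond the scatter, with any drift toward weaker inhibition. For compound 3 the estimated value is 28000 nM, with an expected range of 10000 nM to 50000 nM.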

Compound 3, half-maximal inhibitory concentration: 34700 nM
Estimate against measurement, compound 3: 1.2-fold (0.09 log units) below, and the stated range covers the measured number.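

In this assay, the change to 4-bromophenyl gives a 1.5-fold higher number from compound 2 to compound 3 (0.17 log units; within the scatter), so bromo at this place on the ring does not separate compound 3 from compound 2. Adding methyl to the shared core gives an at least 1.4-fold lower number from compound 1 to compound 3 (0.15 log units; that floor lies within the scatter), which leaves the size of that step unsettled. Compound 1 remains a limit and not a number: the limit of > 50000 nM in this assay, at which 1 of the 3 values shown sits.

On these data alone, how an amine or a carboxylic acid at the same place would read remains open. The compounds shown also leave open whether any group here moves the number beyond the scatter.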